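The source may hold more compounds than are shown below. What is called first, only, known or untested is meant among the compounds shown, and "the series" means these compounds.

Series notes. Compound 1 `O=C(Nc1ccc(OC(F)(F)F)cc1)c1cc(=O)[nH]c2cc(Br)ccc12` and compound 2 `COc1ccc2c(C(=O)Nc3cc(F)cc(F)c3)cc(=O)[nH]c2c1` share the amide-linked core of compound 3 `COc1ccc(-c2ccc3c(C(=O)Nc4cccc(F)c4)cc(=O)[nH]c3c2)cc1` but reach only the limit in a functional assay on KYSE-410 cells (Homo sapiens) for antiproliferative activity, read by MTT assay, with a stated time of 72 h; on this read-out higher numbers stand for weaker inhibition and lower numbers for stronger inhibition. Compound 1 gives > 20000 nM, a limit of the assay rather than a number. Compound 2 likewise gives > 20000 nM, also a limit. Going by the values given here, compound 3 is the only member with a numerical value in this assay, 18000 nM. The other two results, those of compound 1 and compound 2, sit at the limit (the limit of > 20000 nM in this assay, at which 2 of the 3 values shown sit). Compound 4 `C#Cc1ccc2c(C(=O)Nc3cccc(F)c3)cc(=O)[nH]c2c1` differs from compound 3 by ethynyl in place of 4-methoxyphenyl on an aromatic carbon. Among the compounds with values here, no measured step between compounds differing in one place exists to guide this change. Relative to compound 3, compound 4 is expected to show a step of a 1.1-fold higher number from compound 3 to compound 4 (0.05 log units; within the scatter) within the scatter, with a fair chance of a limit only. Compound 4 is estimated at 20000 nM, range 5000 nM to 80000 nM.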

Compound 4, half-maximal inhibitory concentration: 9700 nM
For compound 4 the middle estimate is 2.1-fold (0.31 log units) above the measured one, within the range that was stated.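

In this assay, exchanging 4-methoxyphenyl for the much smaller ethynyl gives a 1.9-fold lower number from compound 3 to compound 4 (0.27 log units; within the scatter). At this aromatic carbon, the ring of 4-methoxyphenyl is therefore not needed for a measurable value, and this change gives no step beyond the scatter. Numerical values are still confined to this pair, and the remaining results are limits, not numbers: the limit of > 20000 nM in this assay, at which 2 of the 4 values shown sit.

Going by these compounds, what an amine or a carboxylic acid on this aromatic carbon would give remains open. So does whether a longer chain here would move the value beyond the scatter.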